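The compounds below may be only part of what the source reports. "The series", "measured", "known", "first", "only" and "open" are said of these compounds alone.

Measured compounds:
- compound 1 `Nc1ccccc1NC(=O)c1ccc(CSC(=S)N2CCN(c3cccnc3)CC2)cc1`: in a functional assay on MGC-803 cells (Homo sapiens) for antiproliferative activity, read by CCK-8 assay, with a stated time of 72 h, tested at 8 uM (on this read-out higher numbers stand for a stronger effect at the one concentration tested and lower numbers for a weaker effect), compound 1 gives 76.9%
- compound 2 `CN(C(=S)SCc1ccc(C(=O)Nc2ccccc2N)cc1)c1cccnc1`: in this assay compound 2 gives 82.5%

Among the compounds with values here, compound 1 stands within the scatter of compound 2, the only other measured compound, so the two numbers cannot be told apart. Compound 3 `Nc1ccccc1NC(=O)c1ccc(CSC(=S)N2CCN(C3CCCCC3)CC2)cc1` differs from compound 1 in one place: cyclohexyl in place of pyridin-3-yl on an amine nitrogen in a ring. Within the data shown here, no measured pair shows this change, so there is nothing to draw on beyond the two numbers themselves. The expected step is a number 4.9 percentage points lower from compound 1 to compound 3 (within the scatter), none beyond the scatter, with some risk of a smaller read-out. Compound 3 is expected to give 72% in this assay, with a range from 50% to 88%.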

Compound 3, a percentage reported as inhibition, at one concentration (the size of the read-out at that concentration, not a potency): 75.3%
Compound 3: the middle estimate sits 3.3 percentage points below what was measured; the range from low to high includes it.
By their numbers in this assay, from the lowest: compounds 3, 1 and 2 (each within the scatter of the next).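

In this assay the change to cyclohexyl at this place, on an amine nitrogen in a ring, gives a number 1.6 percentage points lower from compound 1 to compound 3 (within the scatter). At the one concentration tested, the aromatic ring and ring nitrogen of pyridin-3-yl are therefore not required to retain a read-out of this size. Nothing measured here explains this result.

Going by these compounds, whether a benzyl group or a chain ending in a carboxylic acid on this nitrogen would hold the read-out remains open. A single-concentration read-out also leaves the potencies of compound 1 and compound 3 open.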